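The source may report more compounds than this note shows. Statements on the series, on what has been measured and on what is new or still open speak of the compounds shown alone.

Three measured compounds share one core. Compound 1 `COc1cc(C(=O)NNC(=S)Nc2csc(-c3ccccc3)c2)cc(OC)c1OC` gives 43000 nM in a functional assay on MCF7 cells (Homo sapiens) for inhibition, read by colorimetric assay and MTT assay, with a stated time of 72 h; on this read-out higher numbers stand for weaker inhibition and lower numbers for stronger inhibition. Compound 2 `COc1cc(C(=O)NNC(=S)Nc2csc(-c3ccc(C)cc3)c2)cc(OC)c1OC` gives 31000 nM in this assay, and compound 3 `COc1cc(OC)cc(C(=O)NNC(=S)Nc2csc(-c3ccc(C)cc3)c2)c1` gives 26000 nM in this assay. Compound 2 stands second highest of the three numbers: its nearest neighbour is compound 3, with a 1.2-fold lower number from compound 2 to compound 3 (0.08 log units; within the scatter), and its furthest is compound 1, with a 1.4-fold lower number from compound 1 to compound 2 (0.14 log units; within the scatter). Both steps fall within the scatter, so the three compounds cannot be ranked against each other.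

Compound 4 `COc1ccc(C(=O)NNC(=S)Nc2csc(-c3ccc(C)cc3)c2)cc1OC` has not been measured. Against compound 2 the difference is hydrogen in place of methoxy on an aromatic carbon.

Among the measured compounds shown here, only one measured step bears on this change: the one from compound 2 to compound 3, which is also a hydrogen in place of methoxy on an aromatic carbon, and it gave a 1.2-fold lower number from compound 2 to compound 3 (0.08 log units; within the scatter). That step stayed within the scatter. For the measured compounds named here, the methyl change from compound 1 to compound 2, a 1.4-fold lower number from compound 1 to compound 2 (0.14 log units; within the scatter), likewise stayed within the scatter, so nothing so far has moved the numbers beyond the scatter.

For compound 4 a step of a 1.0-fold lower number from compound 2 to compound 4 (0.01 log units; within the scatter) in this assay is therefore expected, with no direction beyond the scatter. The expected value for compound 4 is 30000 nM, estimated between 15000 nM and 60000 nM.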

Compound 4, half-maximal inhibitory concentration: 11000 nM
Compound 4: the middle estimate sits 2.7-fold (0.44 log units) above what was measured; the whole stated range lies above it.
By their numbers in this assay, from the lowest: compound 4; then compounds 3, 2 and 1 (each within the scatter of the next).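

Taking a methoxy off this aromatic carbon, the one ortho to a methoxy group and meta to the large group, gives the first step in the series that clears the scatter in this assay: a 2.8-fold lower number from compound 2 to compound 4 (0.45 log units; beyond the scatter). Among the compounds shown here, the same exchange of methoxy for hydrogen on a different carbon of that ring stayed within the scatter, at a 1.2-fold lower number from compound 2 to compound 3 (0.08 log units; within the scatter), so the earlier compounds gave no sign that this change could move the number at all, and the effect cannot be read as belonging to the exchange in general. The step is modest and rests on a single pair, so it marks this position as the one place in the ring so far where the number responds, and no more than that.

From the compounds shown here alone, whether hydrogen itself matters at this carbon or only the absence of methoxy remains open, as a fluorine, a hydroxyl, an amine or a longer chain such as ethoxy in the same place would be needed to separate the two. No measurement at hand bears on the reason for this step.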